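The source may hold more compounds than are shown below. What is called first, only, known or untested is meant among the compounds shown, and "the series" means these compounds.

Measured compounds:
Compound 1 `O=C(Nc1cccc(Oc2nccc(C(F)(F)F)c2Cl)c1)C1CCCN(C(=O)c2cc(C(F)(F)F)cc(C(F)(F)F)c2)C1` — 0%
Compound 2 `O=C(Nc1ccc(Cl)cc1)C1CCCN(C(=O)c2cccc(-c3ccco3)c2)C1` — 0%
Compound 3 `Cc1cccc(C(=O)N2CCCC(C(=O)Nc3ccc(Cl)cc3)C2)c1` — 0%

In an ADME assay on PC-3 cells (Homo sapiens) for cytotoxicity, read by WST assay, tested at 100 uM (on this read-out higher numbers stand for more inhibition at the one concentration tested (going by the name of the read-out) and lower numbers for less inhibition), compound 1 gives 0%. On this read-out compound 1 stands level with compound 2 and compound 3, both of which share its core and both of which also give no measurable inhibition at the single concentration tested. Among the compounds with values here, the one step measured within this set, no change at the digits printed from compound 2 to compound 3 (within the scatter), exchanged a group on the aromatic ring attached to the carbonyl of the core and left the read-out unchanged within the scatter.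

Compound 4 `Cc1nc(-c2cccc(NC(=O)C3CCCN(C(=O)c4cc(C(F)(F)F)cc(C(F)(F)F)c4)C3)c2)cs1` differs from compound 1 at the other aryl ring: 2-methyl-1,3-thiazol-4-yl in place of (3-chloro-4-(trifluoromethyl)pyridin-2-yl)oxy on an aromatic carbon. Within the data shown here, no measured step in this set touches that position, so the step from compound 1 to compound 4 has no direct precedent. Among the measured compounds shown here, what the data do show is that every variation so far, including no change at the digits printed from compound 2 to compound 3 (within the scatter), has kept the read-out at the floor, and compound 1, compound 2 and compound 3 all sit at zero inhibition. The expected step of a number 2 percentage points higher from compound 1 to compound 4 (within the scatter) is therefore none beyond the scatter. Compound 4 is estimated at 2% in this assay, with a range from -8% to 15%.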

Compound 4, a percentage reported as inhibition, at one concentration (the size of the read-out at that concentration, not a potency): 1%
The estimate for compound 4 lay 1 percentage points above the measured number; the range from low to high includes it.
By their numbers in this assay, from the lowest: compounds 1, 2, 3 and 4 (each within the scatter of the next).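

Within the data shown here, exchanging the (3-chloro-4-(trifluoromethyl)pyridin-2-yl)oxy group for 2-methyl-1,3-thiazol-4-yl gave a number 1 percentage points higher from compound 1 to compound 4 (within the scatter) in this assay and so provides the first reading at this place, on an aromatic carbon of a six-membered aromatic ring of carbon only and meta to a large group. The change was a substantial one: a group of 12 heavy atoms carrying chlorine and fluorine, built on a six-membered aromatic ring, gave way to one of 6 heavy atoms carrying sulfur, built on a five-membered aromatic ring, and the read-out still did not move beyond the scatter. Nothing available gives a cause for this outcome or shows what either group does in these cells.

As far as these compounds go, with all four compounds at the low end of the read-out, it remains open whether any group on this aromatic carbon could raise the inhibition at the one concentration tested, for instance a primary amine or a carboxylic acid. Also open, from the compounds shown here alone, is what a morpholine or a longer alkyl chain would do at the other aromatic ring of compound 4 .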